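Cytotoxicity of a triazole sulfonamide series on gastric cells

This account rests on a few compounds, and the source may have more. Where it says the series, first, only, none or still open, it means among the compounds named here.

Compound 1 `Cc1cccc(-n2cc(-c3ccccc3NS(=O)(=O)c3c[nH]c(=O)[nH]c3=O)nn2)c1` gives 23700 nM in an ADME assay on GES1 cells (Homo sapiens) for cytotoxicity, read by MTT assay, with a stated time of 24 h; on this read-out lower numbers stand for higher toxicity in this test and higher numbers for lower toxicity in this test. Compound 2 `O=c1[nH]cc(S(=O)(=O)Nc2ccccc2-c2cn(-c3cccc(F)c3)nn2)c(=O)[nH]1` is recorded in this assay as "not toxic" (no number reported). Compound 3 `O=c1[nH]cc(S(=O)(=O)Nc2ccccc2-c2cn(-c3ccc(F)cc3)nn2)c(=O)[nH]1` likewise stands in this assay as "not toxic" (no number reported), so no single number describes where it sits, and the same is true of compound 2. Compound 4 `O=c1[nH]cc(S(=O)(=O)Nc2ccccc2-c2cn(-c3ccccc3Cl)nn2)c(=O)[nH]1` differs from compound 3 by 2-chlorophenyl in place of 4-fluorophenyl on an aromatic nitrogen. Within the data shown here, no measured step of this kind is available, and compound 1, the only compound with a number, gives a value that is not low. Compound 4 is therefore expected to show no change beyond the usual scatter of this assay, and it may again be reported without a number. Compound 4 is expected to give about 30000 nM, in a range from 10000 nM to 100000 nM.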

Compound 4, half-maximal cytotoxic concentration: 20800 nM
For compound 4 the middle estimate is 1.4-fold (0.16 log units) above the measured one; the range from low to high includes it.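

In this assay compound 4 receives a number where compound 3 has none, so the steps to compound 4 from compound 2 and from compound 3 cannot be read. Placing 2-chlorophenyl instead of 3-methylphenyl on the aromatic nitrogen gives a 1.1-fold lower number from compound 1 to compound 4 (0.06 log units; within the scatter), the first readable step at this position. No measurement shown here bears on this result.

Going by these compounds, it remains open how an aryl group carrying an amine or a carboxylic acid would read in this assay. On these data alone, a longer alkyl chain on this nitrogen also remains open.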